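Side chain exchange: from compound 3 to compound 4

This account rests on a few compounds, and the source may have more. Where it says the series, first, only, none or still open, it means among the compounds named here.

Compound 1 `Cn1ncc(Cl)c1-c1cc(C(=O)N[C@@H]2CN[C@H](CCn3cncn3)C[C@H]2c2ccc(Cl)c(Cl)c2)oc1Cl`: 560 nM
Compound 2 `Cn1ncc(Cl)c1-c1cc(C(=O)N[C@@H]2CN[C@H](CCN3CCCCC3)C[C@H]2c2ccc(Cl)c(Cl)c2)oc1Cl`: 1020 nM
Compound 3 `C=CC[C@@H]1C[C@@H](c2ccc(Cl)c(Cl)c2)[C@H](NC(=O)c2cc(-c3c(Cl)cnn3C)c(Cl)o2)CN1`: 780 nM

All of these values come from a functional assay on HCT-116 cells (Homo sapiens) for antiproliferative activity, read by sulforhodamine B assay, with a stated time of 72 h; a lower number here means a stronger inhibitor, a higher number a weaker inhibitor. Compound 3 stands within the scatter of both other compounds: the data show a 1.4-fold higher number from compound 1 to compound 3 (0.14 log units; within the scatter) and a 1.3-fold lower number from compound 2 to compound 3 (0.12 log units; within the scatter).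

Compound 4 `Cn1ncc(Cl)c1-c1cc(C(=O)N[C@@H]2CN[C@H](CC(=O)NCCO)C[C@H]2c2ccc(Cl)c(Cl)c2)oc1Cl` has (2-hydroxyethyl)carbamoyl in place of vinyl on a saturated chain carbon bound to a saturated ring carbon.

The two steps to compound 3 exchange groups at this same place, and a 1.8-fold higher number from compound 1 to compound 2 (0.26 log units; within the scatter) also changes the group carried on this chain. None of these steps leaves the scatter, so the chain has so far shown no measurable effect on this assay. Among the measured compounds shown here, no measured compound carries (2-hydroxyethyl)carbamoyl, which leaves the range wide. No change beyond the scatter is expected, and the estimated outcome is a 1.0-fold higher number from compound 3 to compound 4 (0.01 log units; within the scatter). The estimate for compound 4 is 800 nM, with an expected range of 350 nM to 1900 nM.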

Compound 4, half-maximal inhibitory concentration: 670 nM
Beside the measured number, compound 4's estimate is 1.2-fold (0.08 log units) above it; low and high end bracket the measured number.
By their numbers in this assay, from the lowest: compounds 1, 4, 3 and 2 (each within the scatter of the next).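

In this assay, the (2-hydroxyethyl)carbamoyl group, which carries hydrogen-bond donors and acceptors where vinyl has none, gives a 1.2-fold lower number from compound 3 to compound 4 (0.07 log units; within the scatter). Against the two ring-bearing chains, the same group gives a 1.5-fold lower number from compound 2 to compound 4 (0.18 log units; within the scatter) and a 1.2-fold higher number from compound 1 to compound 4 (0.08 log units; within the scatter), so an open-chain amide with a terminal hydroxyl also stays within the scatter of the other three compounds, and the four groups at this place remain indistinguishable on this read-out. Nothing available here accounts for this flat response.

On these data alone, it remains open whether a carboxylic acid, a primary amine or a chain longer than ((2-hydroxyethyl)carbamoyl)methyl at this place would move the number beyond the scatter. All four compounds share one core and one dichlorophenyl group, so the same insensitivity cannot be assumed for a different core.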